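Thiophen-2-yl to ethynyl on a nucleoside core

This account rests on a few compounds, and the source may have more. Where it says the series, first, only, none or still open, it means among the compounds named here.

Compound 1 `C#Cc1cn([C@@H]2O[C@H](CO)[C@@H](O)[C@H]2O)c2ncnc(C)c12`: 1440 nM
Compound 2 `COc1nc(N)nc2c1c(-c1cccs1)cn2[C@@H]1O[C@H](CO)[C@@H](O)[C@H]1O`: > 100000 nM
Compound 3 `Cc1ncnc2c1c(-c1cccs1)cn2[C@@H]1O[C@H](CO)[C@@H](O)[C@H]1O`: > 100000 nM

In an ADME assay on MRC5 cells (Homo sapiens), read by MTT assay, with a stated time of 72 h (a lower number here means a stronger inhibitor, a higher number a weaker inhibitor), compound 1 gives 1440 nM. For compound 3 the value of > 100000 nM is a limit of the assay and not a number. For compound 2 the value of > 100000 nM is likewise a limit. Two of the three values therefore sit at that limit (the limit of > 100000 nM in this assay, at which 2 of the 3 values shown sit).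

Compound 3 and compound 1 differ in one place: ethynyl in place of thiophen-2-yl on an aromatic carbon. That change made an at least 69-fold lower number from compound 3 to compound 1 (1.84 log units; beyond the scatter). Compound 4 `C#Cc1cn([C@@H]2O[C@H](CO)[C@@H](O)[C@H]2O)c2nc(N)nc(OC)c12` is not yet measured and differs from compound 2 by the same change, (ethynyl in place of thiophen-2-yl on an aromatic carbon). The cores of compound 2 and compound 3 differ as well, but that difference is not broken down here.

For compound 4 a step of similar size is expected in this assay, an at least 33-fold lower number from compound 2 to compound 4 (1.52 log units; beyond the scatter). That expectation rests on compound 3 and compound 1, where the same change made an at least 69-fold lower number from compound 3 to compound 1 (1.84 log units; beyond the scatter). Since compound 2 shows only a limit, the starting point is uncertain, and the estimate is wide. The estimated value of compound 4 is 3000 nM, most likely between 800 nM and 30000 nM.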

Compound 4, half-maximal inhibitory concentration: > 100000 nM
Compound 4 gave a limit, no number (the forecaster's own chance of this, stated with the estimate: 25%); middle value at least 33-fold (1.52 log units) away from the limit.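

In this assay compound 4 gives > 100000 nM, which is a limit of the assay and not a number. Compound 2 also stands at a limit, so no step can be read from compound 2 to compound 4: the limit of > 100000 nM in this assay, at which 3 of the 4 values shown sit. The compounds shown leave open whether ethynyl in place of thiophen-2-yl changes anything on the core of compound 2.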